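Removing the phenyl from a benzyl-substituted oxadiazole series

A few compounds are considered here, and "the series" means these few. Any claim that something is new, unique, unknown or untested is made for them only; others in the source may bear on it.

The account concerns a small set of compounds that share one core, examined in a functional assay on PC-3 cells (Homo sapiens) for cytotoxicity, read by MTT assay; a higher number here means a weaker inhibitor, a lower number a stronger inhibitor. Compound 1, `c1ccc(Cc2nnc(-c3c[nH]c4ccccc34)o2)cc1`, carries a benzyl group on the five-membered ring attached to the indole. In this assay compound 1 gives > 1000000 nM, which is a limit of the assay and not a number. Compound 2, `COc1ccc(-c2nnc(-c3c[nH]c4ccccc34)o2)c(OC)c1OC`, and compound 3, `COc1cc(-c2nnc(-c3c[nH]c4ccccc34)o2)ccc1OCc1ccccc1`, carry substituted phenyl groups at the same position of the core. Compound 2 reaches only > 1000000 nM, again a limit rather than a number. Compound 3 likewise gives > 1000000 nM, a limit. So compound 1 stands together with both other compounds at the boundary of what this assay can report, as summarised by the limit of > 1000000 nM in this assay, at which 3 of the 3 values shown sit; no order among the three can be read from the data.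

The step to compound 4, `Cc1nnc(-c2c[nH]c3ccccc23)o1`, is the change (hydrogen in place of phenyl on a saturated chain carbon bound to an aromatic carbon). For the measured compounds named here, no measured pair in this set shows this kind of change, so its size cannot be taken from a step already seen. Given that every compound so far sits at the limit, compound 4 is expected to show no shift beyond the scatter, a step of a number no higher from compound 1 to compound 4 (the limit leaves the size open) from compound 1. Compound 4 is therefore estimated at 1000000 nM, within a range from 300000 nM to 3000000 nM.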

Compound 4, half-maximal inhibitory concentration: > 1000000 nM
Compound 4 was reported as a limit; the forecaster's own chance of this, stated with the estimate: 80%; the middle value lies on the limit itself.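

Compound 4, like compound 1, is reported only as a limit, so no step from compound 1 to compound 4 can be read in this assay: the limit of > 1000000 nM in this assay, at which 4 of the 4 values shown sit.

The compounds shown leave open whether benzyl to methyl has any effect on this read-out, and which compound with the shared core, if any, would give a readable number.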